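The compounds below may be only part of what the source reports. "The series", "measured", "known", "first", "only" and "open" are said of these compounds alone.

Compound 3 `COC(=O)/C=C/c1cccc(N(Cc2ccc(-c3ccc(F)c(Cl)c3)cc2)C(=O)C2CCCCC2)c1` gives the lowest number of the three in an assay on isolated protein with Bile acid receptor (Homo sapiens) as the target (a higher number here means that more compound is needed for the effect, a lower number that less compound is needed), at 66 nM. Within the data shown here, compound 2 `COC(=O)/C=C/c1cccc(N(Cc2ccc(-c3cccc(C)c3)cc2)C(=O)C(C)C)c1` gives 163 nM in this assay, and compound 1 `COC(=O)/C=C/c1cccc(N(Cc2ccc(/C=C/c3scnc3C)cc2)C(=O)C(C)C)c1` gives 228 nM; the only single-point step among them, a 1.4-fold lower number from compound 1 to compound 2 (0.15 log units; within the scatter), concerns the aryl substituent, not the amide. Compound 4 `COC(=O)/C=C/c1cccc(N(Cc2ccc(-c3ccc(F)c(Cl)c3)cc2)C(=O)C(C)C)c1` differs from compound 3 by isopropyl in place of cyclohexyl on a carbonyl carbon. Among the measured compounds shown here, no measured step in this assay touches the group on the carbonyl carbon, so the data give no direction for this change. Compound 4 is therefore expected to sit near compound 3, with the step of a 1.7-fold higher number from compound 3 to compound 4 (0.22 log units; within the scatter) estimated as modest and uncertain in direction. The estimate for compound 4 in this assay is 110 nM, within 35 nM to 350 nM.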

Compound 4, half-maximal effective concentration: 129 nM
For compound 4 the middle estimate is 1.2-fold (0.07 log units) below the measured one, and the stated range covers the measured number.
By their numbers in this assay, from the lowest: compounds 3, 4, 2 and 1 (each within the scatter of the next, the first and the last beyond it).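

In this assay, among these compounds, the first step at this position, a 2.0-fold higher number from compound 3 to compound 4 (0.29 log units; within the scatter), stays within the scatter, so cyclohexyl and isopropyl on a carbonyl carbon are not told apart here. With isopropyl in place, the steps of a 1.3-fold lower number from compound 2 to compound 4 (0.10 log units; within the scatter) and a 1.8-fold lower number from compound 1 to compound 4 (0.25 log units; within the scatter) also stay within the scatter, so the three aryl-side groups are not told apart either. Nothing shown bears on a cause for these results. As far as these compounds go, whether a phenyl, a tert-butyl or a longer chain on the carbonyl carbon would behave like cyclohexyl or isopropyl remains open.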